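From cyclobutyl to cyclohexylmethyl on an amide-type nitrogen

The compounds below may be only part of what the source reports. "The series", "measured", "known", "first", "only" and "open" are said of these compounds alone.

In an ADME assay on MRC5 cells (Homo sapiens) for inhibition, with a stated time of 72 h (a lower number here means that less compound is needed, a higher number that more compound is needed for the effect), compound 1 (`COc1cccc(OC)c1C(=O)Nc1c[nH]nc1C(=O)NC1CCC1`) gives > 50000 nM, which is a limit of the assay and not a number. Compound 3 (`CO[C@H]1CC[C@H](NC(=O)c2n[nH]cc2NC(=O)c2ccc(N3CCCC3)cc2)CC1`) also gives only a limit, > 50000 nM. Compound 2 (`CO[C@H]1CC[C@H](NC(=O)c2n[nH]cc2NC(=O)c2ccccc2)CC1`) gives a measured 800 nM. Compound 1 therefore has no number of its own and stands with the limit of > 50000 nM in this assay, at which 2 of the 3 values shown sit.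

Compound 4 (`COc1cccc(OC)c1C(=O)Nc1c[nH]nc1C(=O)NCC1CCCCC1`) keeps the core of compound 1 and differs from it in one place: cyclohexylmethyl in place of cyclobutyl on an amide-type nitrogen. Among the measured compounds shown here, the only measured step, an at least 62-fold higher number from compound 2 to compound 3 (1.79 log units; beyond the scatter), is large and beyond the scatter. It concerns pyrrolidin-1-yl in place of hydrogen on an aromatic carbon, however, and not the amide-type nitrogen, so it says little about this change. For the measured compounds named here, no measured step alters the group on that nitrogen. Compound 2, with 800 nM, shows only that this assay can return a number for a compound of this kind, so a modest move towards a lower number is possible, but no large step is expected. The expected change is an at least 1.2-fold lower number from compound 1 to compound 4 (0.09 log units; that floor lies within the scatter). For compound 4 the estimated value is 40000 nM, with an expected range from 12000 nM to 100000 nM.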

Compound 4, half-maximal effective concentration: > 50000 nM
Compound 4 was reported as a limit; the forecaster's own chance of this, stated with the estimate: 60%; middle value at least 1.2-fold (0.09 log units) from the limit.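

In this assay compound 4 gives > 50000 nM, a limit of the assay and not a number. Compound 1 also gives only a limit, > 50000 nM, so no step can be read from compound 1 to compound 4. The compounds shown leave open whether cyclohexylmethyl in place of cyclobutyl on the amide-type nitrogen changes the number in this assay at all.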